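The source may report more compounds than this note shows. Statements on the series, on what has been measured and on what is new or still open speak of the compounds shown alone.

Of the compounds shown here, two that share a common core have been tested in a functional assay on OVCAR-8 cells (Homo sapiens) for cytotoxicity, read by sulforhodamine B assay, with a stated time of 48 h, tested at 1 uM; a lower number here means a stronger effect, a higher number a weaker effect of the compound at the concentration tested. Compound 1 `COc1ccc(-c2cc(/C=C/C(=O)c3ccc(N)cc3)[nH]n2)cc1` gives 76% in this assay, and compound 2 `COc1cc(-c2cc(/C=C/C(=O)c3ccc(Cl)c(Cl)c3)[nH]n2)cc(OC)c1OC` gives 88%. Of the two, compound 1 shows the lower number, with compound 2 lying higher by a gap beyond the usual scatter. Because these two differ in more than one place, nothing can be read from the pair about any single change.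

Compound 3 `COc1ccc(-c2cc(/C=C/C(=O)c3ccc(N)cc3)[nH]n2)cc1OC` is built from compound 1 by one change: methoxy in place of hydrogen on an aromatic carbon. Among the measured compounds shown here, no pair that differs only in this way has been measured, so the expected size of the step rests only on the two values shown. Given that compound 2 gives 88% with additional methoxy groups, the expected step from compound 1 to compound 3 in this assay is a small move toward a weaker effect, a number 4 percentage points higher from compound 1 to compound 3 (within the scatter), possibly none beyond the scatter. Compound 3 is therefore estimated to give 80% in this assay, within a range from 62% to 95%.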

Compound 3, a percentage reported as activity, at one concentration (the size of the read-out at that concentration, not a potency): 93%
Estimate against measurement, compound 3: 13 percentage points below; low and high end bracket the measured number.
By their numbers in this assay, from the lowest: compound 1; then compounds 2 and 3 (each within the scatter of the next).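

In this assay, putting methoxy in place of hydrogen on an aromatic carbon, ortho to a methoxy group and meta to a large group, gives a number 17 percentage points higher from compound 1 to compound 3 (beyond the scatter). Compound 1 and compound 3 differ in one place only, so this pair shows that this single change weakens the effect at the concentration tested, something the earlier pair could not show. Nothing measured for these compounds bears on the reason for this step.

As far as these compounds go, it remains open whether a hydroxyl group, a fluorine atom or an ethoxy group on this same carbon would shift the number in the same way. Also open, from the compounds shown here alone, is whether the methoxy step would keep its size if a nitrile took the place of the amine in compound 1 and compound 3.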